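This account rests on a few compounds, and the source may have more. Where it says the series, first, only, none or still open, it means among the compounds named here.

Of the compounds shown here, three have been tested in a functional assay on the whole organism for inhibition, with Rattus norvegicus as the target, read by paw edema, with a stated time of 30 min, at a dose of 40 mg/kg by the oral route; on this read-out lower numbers stand for a weaker effect and higher numbers for a stronger effect at the one dose given. Compound 1 `Fc1ccc(OCC2=NCCO2)cc1` gives 30.2%, compound 2 `O=[N+]([O-])c1ccccc1OCC1=NCCO1` gives 35.5%, and compound 3 `O=[N+]([O-])c1ccc(OCC2=NCCO2)cc1` gives 30.4%. All three values lie within the usual scatter of one another, so no ordering among them can be read from these numbers.

One comparison among the measured compounds isolates a single structural change. Compound 1 is obtained from compound 3 by the change (fluoro in place of nitro on an aromatic carbon), and this change gives a number 0.2 percentage points lower from compound 3 to compound 1 (within the scatter), a step that does not reach beyond the scatter.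

Compound 2 and compound 3 contain the same atoms joined differently; the difference between these two cores is not broken down here.

Compound 4 `Fc1ccccc1OCC1=NCCO1` has not yet been measured. It is obtained from compound 2 by the change (fluoro in place of nitro on an aromatic carbon). Going by the values given here, this is the same kind of change as the one from compound 3 to compound 1, but the place differs: here the group sits ortho to a group of 7 heavy atoms, whereas from compound 3 to compound 1 it sat para to a group of 7 heavy atoms. Because that earlier change gave a number 0.2 percentage points lower from compound 3 to compound 1 (within the scatter), the expected step here is a number 0.5 percentage points lower from compound 2 to compound 4 (within the scatter), resting on this one comparison. In this assay compound 4 is therefore estimated at 35%, expected to fall between 25% and 45%.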

Compound 4, a percentage reported as inhibition, in the whole organism at one dose (the size of the read-out at that dose, not a potency): 30.5%
Compound 4: the middle estimate sits 4.5 percentage points above what was measured; measured number inside the range.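

In this assay, fluoro in place of nitro gives a number 5 percentage points lower from compound 2 to compound 4 (within the scatter) on the core of compound 2, and this step can be set beside the same change on the core of compound 3, where the two steps do not differ: the same change on two cores in this assay, a number 0.2 percentage points lower (within the scatter) from compound 3 to compound 1 and a number 5 percentage points lower (within the scatter) from compound 2 to compound 4, 4.8 percentage points apart, within the scatter of two such steps. On these two cores, then, the change can be carried from one to the other with no sign that the core alters its outcome. This does not show that the two groups are equivalent in general, since both steps are small against the scatter and two cores say nothing about a third core or about other doses.

Going by these compounds, it remains open how a different group on the aromatic ring, such as an amine or a carboxylic acid, would read in this assay on either core. Also open, on these data alone, is whether a longer chain joining the aromatic ring to the rest of the molecule would move the number beyond the scatter.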